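Chloro for ethyl on a growth inhibitor

The compounds below may be only part of what the source reports. "The series", "measured", "known", "first", "only" and "open" are said of these compounds alone.

Among the compounds with values here, in a functional assay on A549 cells (Homo sapiens) for inhibition, read by CCK-8 assay, with a stated time of 72 h, tested at 8 uM (a higher number here means more inhibition of growth at the concentration tested, a lower number less inhibition of growth), compound 1 (`CCc1ccc(SCc2ccc(C(=O)Nc3ccccc3N)cc2)cc1`) gives 91.4% as the highest of the three numbers so far, and both others lie beyond the scatter from it. Compound 2 (`Nc1ccccc1NC(=O)/C=C/c1ccc(CSc2ccc(F)cc2)cc1`) gives 59.1% and compound 3 (`Nc1ccccc1NC(=O)c1ccc(CSc2ccc(C(F)(F)F)cn2)cc1`) gives 38.9% in the same test. Compound 4 (`Nc1ccccc1NC(=O)c1ccc(CSc2ccc(Cl)cc2)cc1`) keeps the core of compound 1 and differs in one place (chloro in place of ethyl on an aromatic carbon), with chloro in place of ethyl on an aromatic carbon. Within the data shown here, no measured pair isolates a single change, so the evidence for this step is thin. A moderate loss of inhibition, somewhat beyond the scatter, is expected (a number 19.4 percentage points lower from compound 1 to compound 4 (beyond the scatter)). Compound 4 is estimated at 72% (expected range 45% to 92%).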

Compound 4, percent growth inhibition at one concentration: 50.4%
Beside the measured number, compound 4's estimate is 21.6 percentage points above it; low and high end bracket the measured number.
By their numbers in this assay, from the lowest: compound 3; then compounds 4 and 2 (each within the scatter of the next); then compound 1.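

Within the data shown here, this is the first pair that differs in one place only, so the change from 4-ethylphenyl to 4-chlorophenyl can be read on its own: in this assay it gives a number 41 percentage points lower from compound 1 to compound 4 (beyond the scatter) and counts as a large step. With the rest of the molecule held fixed, the group at this position, para to a large group, strongly affects growth inhibition. No available evidence explains this result. A single pair cannot show whether ethyl is especially favourable or chloro especially unfavourable. A propyl chain, a methoxy group or an amine at this position could help separate those two readings.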